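The source may report more compounds than this note shows. Statements on the series, on what has been measured and on what is new or still open speak of the compounds shown alone.

Compounds measured so far, in a functional assay on NIH3T3 cells (Mus musculus); on this read-out higher numbers stand for an effect only at larger amounts of compound and lower numbers for an effect already at smaller amounts:

Compound 1 `COC(=O)[C@H](CCSC)NC(=O)c1ccc(NCc2cncn2Cc2ccc(Cl)cc2)cc1-c1ccccc1`: > 10 uM
Compound 2 `COC(=O)[C@H](CCSC)NC(=O)c1ccc(NCc2cncn2Cc2ccccc2C)cc1-c1ccccc1`: > 10 uM
Compound 3 `CSCC[C@H](NC(=O)c1ccc(NCc2cncn2Cc2cccc(Cl)c2)cc1-c1ccccc1)C(=O)O`: > 10 uM

Each of these three values is a limit of this assay, not a number. Compound 3 therefore stands at the limit of > 10 uM in this assay, at which 3 of the 3 values shown sit, and nothing in the numbers sets it apart from compound 1 or compound 2.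

Compound 4 `CSCC[C@H](NC(=O)c1ccc(NCc2cncn2Cc2ccccc2C)cc1-c1ccccc1)C(=O)O` has not yet been measured. Next to compound 3 it differs by 2-methylphenyl in place of 3-chlorophenyl on a saturated chain carbon bound to an aromatic nitrogen.

Among the compounds with values here, only one measured step bears on this change: a step that the two limits leave unreadable from compound 1 to compound 2. That step exchanges a chlorophenyl for a 2-methylphenyl at the same place, but both of its values are limits, so its size is not readable.

The expectation for compound 4 in this assay is a result at the same limit, with the step that the limit leaves unreadable from compound 3 to compound 4 not readable beyond the scatter. Compound 4 is thus estimated at 20 uM, within 8 uM to 60 uM.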

Compound 4, concentration for half-maximal effect: > 10 uM
Compound 4 was reported as a limit; the forecaster's own chance of this, stated with the estimate: 85%; the middle value does not contradict the limit.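

In this assay compound 4 gives > 10 uM, a limit and not a number. Within the data shown here, no step to compound 4 from compound 2 or compound 3 can be read: the limit of > 10 uM in this assay, at which 4 of the 4 values shown sit. The compounds shown leave open whether either exchange alters the effect in this assay.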